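The source may report more compounds than this note shows. Statements on the series, on what has been measured and on what is new or still open speak of the compounds shown alone.

Compound 1 `O=c1cc(CC(O)(COCc2ccccc2)COCc2ccccc2)[nH]c(=O)[nH]1` gives > 100000 nM in a functional assay on HepG2 cells (Homo sapiens) for antiproliferative activity, read by MTT assay, with a stated time of 72 h (a higher number here means a weaker inhibitor, a lower number a stronger inhibitor), which is a limit of the assay.
Compound 2 `COCn1c(CC(O)(COCc2ccccc2)COCc2ccccc2)cc(=O)[nH]c1=O` gives > 100000 nM in this assay, also a limit.
Compound 3 `O=c1cc(CC(COCc2ccccc2)COCc2ccccc2)[nH]c(=O)[nH]1` gives > 100000 nM in this assay, again a limit.

Compound 3 therefore stands at the limit, not at a number. Compound 4 `COCn1c(CC(COCc2ccccc2)COCc2ccccc2)cc(=O)[nH]c1=O` differs from compound 3 by methoxymethyl in place of hydrogen on an aromatic nitrogen. Among the measured compounds shown here, two measured steps bear on this change: a step that the two limits leave unreadable from compound 1 to compound 2, the same exchange on another compound, and a step that the two limits leave unreadable from compound 1 to compound 3, which links compound 1 to compound 3. Neither has a readable size; all their ends sit at the limit (the limit of > 100000 nM in this assay, at which 3 of the 3 values shown sit). No step beyond the usual scatter is expected for compound 4, and the estimated step that the limit leaves unreadable from compound 3 to compound 4 most likely ends at a limit once more. Compound 4 is expected at 150000 nM in this assay, within 50000 nM to 500000 nM.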

Compound 4, half-maximal inhibitory concentration: > 100000 nM
Compound 4: only a limit was reported (the forecaster's own chance of this, stated with the estimate: 85%); the middle value does not contradict the limit.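

The steps to compound 4 from compound 3 and from compound 2 cannot be read, because all three compounds sit at a limit: the limit of > 100000 nM in this assay, at which 4 of the 4 values shown sit.

The compounds shown leave open whether methoxymethyl or hydroxy changes activity at all in this assay.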